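The source may report more compounds than this note shows. Statements on the series, on what has been measured and on what is new or still open speak of the compounds shown alone.

Of the compounds shown here, three have so far been measured in an assay (Rattus norvegicus) for inhibition of Fatty-acid amide hydrolase 1 (Homo sapiens); on this read-out lower numbers stand for stronger inhibition and higher numbers for weaker inhibition. Compound 1 `Nc1cccc(-c2cnc(C(=O)CCCCCCc3ccccc3)o2)c1` gives 19 nM in this assay, compound 2 `O=C(CCCCCCc1ccccc1)c1ncc(-c2ccc(C(=O)C(F)(F)F)cc2)o1` gives 65 nM, and compound 3 `N#Cc1ccc(-c2cnc(C(=O)CCCCCCc3ccccc3)o2)cc1` gives 40 nM. Compound 3 therefore stands second highest of the three numbers: its nearest neighbour is compound 2, with a 1.6-fold lower number from compound 2 to compound 3 (0.21 log units; within the scatter) lying within the scatter, while a 2.1-fold higher number from compound 1 to compound 3 (0.32 log units; beyond the scatter) is modest but beyond it. Both measured steps alter only the group carried on the phenyl ring of the shared core; neither one removes that ring.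

Compound 4 `CC(=O)c1cnc(C(=O)CCCCCCc2ccccc2)o1` goes further: acetyl in place of 4-cyanophenyl on an aromatic carbon. Going by the values given here, no measured step covers the loss of the whole aryl group, so the two known steps are only an indirect guide. They show that exchanging one group on the phenyl ring for another shifted the numbers little, the larger of them, a 2.1-fold higher number from compound 1 to compound 3 (0.32 log units; beyond the scatter), still being modest. The change leading to compound 4 takes away the ring itself, so a shift larger than either measured step is plausible, and the direction is not settled by the data; the expectation leans toward a higher number in this assay.

Compound 4 is thus expected to give about 160 nM in this assay, with a range from 40 nM to 650 nM. That estimate corresponds to an expected step of a 4.0-fold higher number from compound 3 to compound 4 (0.60 log units; beyond the scatter), wider than either measured one.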

Compound 4, inhibition constant: 2 nM
The estimate for compound 4 lay 80-fold (1.90 log units) above the measured number; the whole stated range lies above it.
By their numbers in this assay, from the lowest: compound 4; then compound 1; then compounds 3 and 2 (each within the scatter of the next).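

On this aromatic carbon, next to the ring oxygen, an aryl group is not needed for a low number in this assay: acetyl in place of 4-cyanophenyl, which removes the six-membered aromatic ring altogether, gives a 20-fold lower number from compound 3 to compound 4 (1.30 log units; beyond the scatter), a large step and far bigger than anything seen between the aryl compounds. Acetyl in place of 3-aminophenyl points the same way, with a 9.5-fold lower number from compound 1 to compound 4 (0.98 log units; beyond the scatter), a modest step that still places compound 4 below the best of the aryl compounds compared here, so the change holds against both aryl groups with a direct step to it. Nothing available on these compounds bears on the reason for this drop in the number.

This exchange removes the aryl ring and brings in a carbonyl in one move, and the compounds shown do not separate the two contributions. Going by these compounds, whether the carbonyl of the acetyl matters remains open, and a methyl group, a methyl ester or a carboxylic acid on the same carbon would address that question.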